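Chloro, Fluoro and Methyl Sulfonamides, and a Bromo Question

A few compounds are considered here, and "the series" means these few. Any claim that something is new, unique, unknown or untested is made for them only; others in the source may bear on it.

Compound 1 `Cc1ccc(S(=O)(=O)NC(C)C2=CC(=O)c3c(O)ccc(O)c3C2=O)cc1` – 5340 nM
Compound 2 `CC(NS(=O)(=O)c1ccc(F)cc1)C1=CC(=O)c2c(O)ccc(O)c2C1=O` – 6410 nM
Compound 3 `CC(NS(=O)(=O)c1ccc(Cl)cc1)C1=CC(=O)c2c(O)ccc(O)c2C1=O` – 810 nM

In a functional assay on HeLa cells (Homo sapiens) for cytotoxicity, read by sulforhodamine B assay (a higher number here means a weaker inhibitor, a lower number a stronger inhibitor), compound 3 holds the lowest of the three numbers, and both others lie beyond the scatter from it. Compound 4 `CC(NS(=O)(=O)c1ccccc1Br)C1=CC(=O)c2c(O)ccc(O)c2C1=O` differs from it by 2-bromophenyl in place of 4-chlorophenyl on a sulfonyl sulfur. Going by the values given here, three measured steps bear on this. a 6.6-fold lower number from compound 1 to compound 3 (0.82 log units; beyond the scatter) and a 7.9-fold lower number from compound 2 to compound 3 (0.90 log units; beyond the scatter) were modest, while a 1.2-fold higher number from compound 1 to compound 2 (0.08 log units; within the scatter) stayed within the scatter. Among the compounds with values here, no measured compound carries 2-bromophenyl, so it is unknown whether the low number of compound 3 (810 nM) carries over. A modest move towards a higher number is therefore expected in this assay. The expected step is a 2.7-fold higher number from compound 3 to compound 4 (0.43 log units; beyond the scatter). For compound 4 the estimated value is 2200 nM. The expected range for compound 4 runs from 600 nM to 7500 nM.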

Compound 4, half-maximal inhibitory concentration: 6200 nM
Beside the measured number, compound 4's estimate is 2.8-fold (0.45 log units) below it; the range from low to high includes it.
By their numbers in this assay, from the lowest: compound 3; then compounds 1, 4 and 2 (each within the scatter of the next).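

The swap of 4-chlorophenyl for 2-bromophenyl on a sulfonyl sulfur in this assay gave a clear loss (a 7.7-fold higher number from compound 3 to compound 4 (0.88 log units; beyond the scatter)), so the low number of compound 3 does not extend to this aryl group. Compound 4 instead matches the other two sulfonamides (a 1.0-fold lower number from compound 2 to compound 4 (0.01 log units; within the scatter); a 1.2-fold higher number from compound 1 to compound 4 (0.06 log units; within the scatter)), which leaves 4-chlorophenyl alone apart from the rest of this set. Nothing measured here accounts for that difference.

Halogen and ring place changed together, so their contributions cannot be separated. Going by these compounds, whether 4-bromophenyl or 2-chlorophenyl would keep the low number remains open.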